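The source may report more compounds than this note shows. Statements on the series, on what has been measured and on what is new or still open speak of the compounds shown alone.

Measured so far:
compound 1 `Cc1ccc2cc(CN(Cc3ccc(F)cc3)Cc3ccc(C(C)C)cc3)c(=O)[nH]c2c1`: > 33000 nM
compound 2 `Cc1ccc2cc(CN(Cc3ccc(F)cc3)Cc3ccc(C(F)(F)F)cc3)c(=O)[nH]c2c1`: > 33000 nM

In a toxicity assay on MDCK cells (Canis lupus familiaris) for cytotoxicity, read by crystal violet staining, with a stated time of 48 h (a lower number here means that less compound is tolerated, a higher number that more compound is tolerated), compound 2 gives only a limit of the assay, not a number. For the measured compounds named here, the one measured step, a step that the two limits leave unreadable from compound 1 to compound 2, is likewise unreadable, because of the limit of > 33000 nM in this assay, at which 2 of the 2 values shown sit. Compound 3 `Cc1ccc2cc(CN(Cc3ccc(F)cc3)C(=O)c3ccccc3)c(=O)[nH]c2c1` differs from compound 2 by benzoyl in place of 4-(trifluoromethyl)benzyl on an amine nitrogen. Going by the values given here, no measured step bears on this change, so no direction can be read for it; the expectation is that compound 3 also stays at the limit, a step of a number no higher from compound 2 to compound 3 (the limit leaves the size open). Compound 3 is estimated at 33000 nM, within 10000 nM to 100000 nM.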

Compound 3, half-maximal cytotoxic concentration: > 33000 nM
Compound 3: no number, only a limit (the forecaster's own chance of this, stated with the estimate: 75%); the middle value sits exactly at the limit.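

Compound 1, compound 2 and compound 3 all give only a limit in this assay, so no step among them can be read: the limit of > 33000 nM in this assay, at which 3 of the 3 values shown sit.

The compounds shown leave open how much compound the cells tolerate beyond that limit, and whether any of these changes on the amine nitrogen alters it.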